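Cytotoxicity notes on the shared-core series

This account rests on a few compounds, and the source may have more. Where it says the series, first, only, none or still open, it means among the compounds named here.

compound 1 `O=C(Nc1ncc(Cc2ccc(F)cc2)s1)c1ccc(Cl)cc1Cl`: > 50000 nM
compound 2 `CCCCC(CC)CNc1ncc(C(Oc2ccc3cc(Br)ccc3c2)c2ccc(Cl)cc2)s1`: "not toxic" (no number reported)

Two compounds have been run in an ADME assay on HepG2 2.2.15 cells (Homo sapiens) for cytotoxicity; on this read-out lower numbers stand for higher toxicity in this test and higher numbers for lower toxicity in this test. Compound 1 `O=C(Nc1ncc(Cc2ccc(F)cc2)s1)c1ccc(Cl)cc1Cl` returns a limit of the assay rather than a number, > 50000 nM. Compound 2 `CCCCC(CC)CNc1ncc(C(Oc2ccc3cc(Br)ccc3c2)c2ccc(Cl)cc2)s1` also returns no single number and is reported only as "not toxic" (no number reported). Where compound 2 stands can therefore be stated only in words: of the two values shown, one sits at the limit of > 50000 nM in this assay, at which 1 of the 2 values shown sits, and compound 2 itself carries no figure at all. Neither measured compound gives any sign of toxicity in this test within the range covered.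

Compound 3 `O=C(Nc1ncc(C(Oc2ccc3cc(Br)ccc3c2)c2ccc(Cl)cc2)s1)c1cc(F)c(F)cc1F` has not yet been measured. Relative to compound 2 it carries (2,4,5-trifluorophenyl)carbonyl in place of 2-ethylhexyl on a nitrogen on an aromatic ring. Within the data shown here, no step between measured compounds is available, so the expectation rests on compound 1, which also bears a carbonyl on a nitrogen on an aromatic ring and reads > 50000 nM as a limit. No shift beyond the usual scatter is expected in this assay in either direction. Compound 3 is expected at 50000 nM, within 20000 nM to 120000 nM, most probably reported again as a limit rather than a number.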

Compound 3, half-maximal cytotoxic concentration: "not toxic" (no number reported)
Compound 3: no number reported, and the estimate cannot be compared.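

Compound 2 and compound 3 are both reported in this assay only as "not toxic", without a number, so no step can be read between them. The compounds shown leave open whether replacing 2-ethylhexyl with (2,4,5-trifluorophenyl)carbonyl changes cytotoxicity at all, and at what concentration, if any, toxicity would appear in this assay.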